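Bis-chromone pair: removing the isobutoxy group

The source may report more compounds than this note shows. Statements on the series, on what has been measured and on what is new or still open speak of the compounds shown alone.

Compound 1 `CC(C)COc1cccc2occ(Cc3coc4ccccc4c3=O)c(=O)c12` is tested in a functional assay on NUGC-3 cells (Homo sapiens) for antiproliferative activity, read by XTT assay (on this read-out lower numbers stand for stronger inhibition and higher numbers for weaker inhibition), and gives only > 10000 nM there, which is a limit of the assay and not a number (the limit of > 10000 nM in this assay, at which 1 of the 2 values shown sits). Compound 2 `Cc1ccc2c(=O)c(Cc3coc4cccc(OCC5CCCCC5)c4c3=O)coc2c1` gives 2150 nM in this assay. Compound 3 `O=c1c(Cc2coc3ccccc3c2=O)coc2ccccc12` differs from compound 1 by hydrogen in place of isobutoxy on an aromatic carbon. For the measured compounds named here, no measured pair covers this change, so its direction is open. A step of the size an at least 1.2-fold lower number from compound 1 to compound 3 (0.09 log units; that floor lies within the scatter) is expected, at most modest and not clearly beyond the scatter. Compound 3 is expected to give about 8000 nM, somewhere between 1500 nM and 30000 nM.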

Compound 3, half-maximal inhibitory concentration: 7770 nM
The estimate for compound 3 lay 1.0-fold (0.01 log units) above the measured number; the range from low to high includes it.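

In this assay, hydrogen in place of isobutoxy on this aromatic carbon reads as an at least 1.2-fold lower number from compound 1 to compound 3 (0.10 log units; that floor lies within the scatter). Compound 3 gives a number without the isobutoxy group, so that group is not required for a measurable value on the shared core. Compound 1 sits at a limit of the assay, so the step is only a floor: the limit of > 10000 nM in this assay, at which 1 of the 3 values shown sits.

From the compounds shown here alone, whether the true step lies beyond the scatter stays open. Also open, going by these compounds, is how an amine or a methoxy group on this aromatic carbon would compare with hydrogen.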